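The source may report more compounds than this note shows. Statements on the series, on what has been measured and on what is new or still open speak of the compounds shown alone.

In a functional assay on BT-549 cells (Homo sapiens) for inhibition, read by sulforhodamine B assay, with a stated time of 6 days (a higher number here means a weaker inhibitor, a lower number a stronger inhibitor), compound 1 `CNCCNCc1cccc(-c2nc(NC3CCOCC3)c(C)c(-c3cncnc3)n2)c1` gives > 50000 nM as its reading, and that is a limit, not a number. In this assay compound 2 `CNCCNCc1cccc(-c2nc(Nc3ccccc3)c(C)c(-c3c(C)nn(C)c3C)n2)c1` reads 8200 nM while compound 3 `CNCCNCc1cccc(-c2nc(-c3c(C)noc3C)c(C)c(N3Cc4cccnc4C3)n2)c1` reads 11900 nM on the same scale. Compound 4 `CNCCNCc1cccc(-c2nc(NC3CCOCC3)c(C)c(-c3ccncc3)n2)c1` changes one place of compound 1: pyridin-4-yl in place of pyrimidin-5-yl on an aromatic carbon. Within the data shown here, no measured pair shows this swap, so only a modest move in this assay toward a stronger inhibitor is expected, with compound 3 at 11900 nM as a rough guide to how far it might reach. The estimated step (an at least 1.6-fold lower number from compound 1 to compound 4 (0.22 log units; that floor lies within the scatter)) is small and uncertain. The estimate for compound 4 is 30000 nM (expected range 10000 nM to 70000 nM).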

Compound 4, half-maximal inhibitory concentration: > 50000 nM
Compound 4 was reported as a limit; the forecaster's own chance of this, stated with the estimate: 50%; middle value at least 1.6-fold (0.22 log units) away from the limit.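

Compound 1 and compound 4 are both reported only as limits in this assay, so no step can be read between them: the limit of > 50000 nM in this assay, at which 2 of the 4 values shown sit.

On these data alone, whether pyridin-4-yl or pyrimidin-5-yl gives the stronger inhibitor remains open.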